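Removing the thiocarbonyl side chain from compound 3

This account rests on a few compounds, and the source may have more. Where it says the series, first, only, none or still open, it means among the compounds named here.

In a functional assay on HT-29 cells (Homo sapiens) for antiproliferative activity, read by MTT assay, with a stated time of 96 h (a lower number here means a stronger inhibitor, a higher number a weaker inhibitor), compound 1 (`CSC(=S)N/N=C1\CC2(CCCCC2)Oc2c1ccc1ccccc21`) gives 4130 nM as its value, compound 2 (`S=C(N/N=C1\CC2(CCCCC2)Oc2c1ccc1ccccc21)N1CCNCC1`) gives 8340 nM and compound 3 (`NCCCCCCC(=S)N/N=C1\CC2(CCCCC2)Oc2c1ccc1ccccc21`) gives 3870 nM at the low end of the three, a place shared with compound 1. The measured steps of a 1.1-fold lower number from compound 1 to compound 3 (0.03 log units; within the scatter) and a 2.2-fold lower number from compound 2 to compound 3 (0.33 log units; beyond the scatter) both exchange groups on a thiocarbonyl carbon. Compound 4 (`N/N=C1\CC2(CCCCC2)Oc2c1ccc1ccccc21`) differs from compound 3 by a hydrogen atom in place of a group of 9 heavy atoms (7 carbon, 1 nitrogen, 1 sulfur; no ring), on an amine nitrogen on an amine nitrogen. For the measured compounds named here, no measured step removes the thiocarbonyl, so these steps bear on this change only loosely. With a 2.2-fold lower number from compound 2 to compound 3 (0.33 log units; beyond the scatter) as the largest step involving compound 3, a modest upward step is expected in this assay rather than a large one. The expected step is a 1.4-fold higher number from compound 3 to compound 4 (0.15 log units; within the scatter) on this reading. Compound 4 is estimated at 5500 nM with a range from 2000 nM to 15000 nM overall.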

Compound 4, half-maximal inhibitory concentration: 9970 nM
The estimate for compound 4 lay 1.8-fold (0.26 log units) below the measured number; measured number inside the range.
By their numbers in this assay, from the lowest: compounds 3 and 1 (each within the scatter of the next); then compounds 2 and 4 (each within the scatter of the next).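

In this assay the bare amine nitrogen now gives a baseline for the side chains, and removing them costs little: a 2.6-fold higher number from compound 3 to compound 4 (0.41 log units; beyond the scatter) and a 2.4-fold higher number from compound 1 to compound 4 (0.38 log units; beyond the scatter) are modest steps beyond the scatter. By contrast, a 1.2-fold higher number from compound 2 to compound 4 (0.08 log units; within the scatter) stays within the scatter, so the piperazin-1-yl side chain shows no measurable gain over hydrogen. The gain over hydrogen is confined to the 6-aminohexyl and methylsulfanyl side chains. Still open, on these data alone, is whether a carboxylic acid or a shorter aminoalkyl chain on the thiocarbonyl carbon would widen that gain. Nothing on hand accounts for these differences.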